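A few compounds are considered here, and "the series" means these few. Any claim that something is new, unique, unknown or untested is made for them only; others in the source may bear on it.

Three amides built on one shared core have been measured in an assay on membranes from brain for binding affinity to metabotropic glutamate receptor 5 (Rattus norvegicus); on this read-out lower numbers stand for stronger inhibition and higher numbers for weaker inhibition. Compound 1 `Cc1cccc(C(=O)Nc2cccc(C)n2)c1` gives 1840 nM. Compound 2 `Cc1cccc(NC(=O)c2cccc(C(F)(F)F)c2)n1` carries a trifluoromethyl in place of the methyl on an aromatic carbon and gives 18700 nM; the step is a 10-fold higher number from compound 1 to compound 2 (1.01 log units; beyond the scatter). Compound 3 `Cc1cccc(NC(=O)c2cccc(OS(C)(=O)=O)c2)n1` carries a (methylsulfonyl)oxy group at that carbon and gives 83600 nM, the highest number of the three: the step is a 45-fold higher number from compound 1 to compound 3 (1.66 log units; beyond the scatter), and a 4.5-fold higher number from compound 2 to compound 3 (0.65 log units; beyond the scatter). Compound 3 is therefore the weakest binder among the three measured.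

Compound 4 `Cc1cccc(NC(=O)c2cccc(Oc3ccccc3)c2)n1` has not yet been measured. It differs from compound 3 in one place: phenyl in place of methylsulfonyl on an oxygen on an aromatic ring. For the measured compounds named here, none of the measured steps exchanges one group on this oxygen for another; each of them replaced the whole substituent on the aromatic carbon, so no measured step bears directly on this change. Going by the values given here, the only guide is that compound 3 sits at the weak end of the set, leaving ample room for the number to fall and little for it to rise, so the expected step is a 5.6-fold lower number from compound 3 to compound 4 (0.75 log units; beyond the scatter), though with wide uncertainty. Compound 4 is thus estimated to give about 15000 nM in this assay, somewhere between 3000 nM and 80000 nM.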

Compound 4, half-maximal inhibitory concentration: 57000 nM
Estimate against measurement, compound 4: 3.8-fold (0.58 log units) below; the measured number falls inside the stated range.
By their numbers in this assay, from the lowest: compound 1; then compound 2; then compounds 4 and 3 (each within the scatter of the next).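

In this assay, the exchange of methylsulfonyl for phenyl on the oxygen on an aromatic ring is a step within the usual scatter (a 1.5-fold lower number from compound 3 to compound 4 (0.17 log units; within the scatter)), so two groups that differ in their counts, one with no ring and hydrogen-bond acceptors and one with an aromatic ring and none, cannot be told apart on this read-out. Phenoxy also extends what the earlier compounds showed at this aromatic carbon: it reads clearly above trifluoromethyl (a 3.0-fold higher number from compound 2 to compound 4 (0.48 log units; beyond the scatter)) and far above methyl (a 31-fold higher number from compound 1 to compound 4 (1.49 log units; beyond the scatter)), so in all three replacements of the methyl of compound 1 the number rises, and no compound shown goes against this. No measurement available here accounts for these values.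

What the four compounds leave open is whether any group at this aromatic carbon can match or beat methyl, for example an ethyl, a chlorine, a methoxy or an amine. On these data alone, it is also open whether a carboxylic acid or a substituted phenoxy would read like compound 4 or move away from it.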